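Working notes: from compound 3 to compound 4

The compounds below may be only part of what the source reports. "The series", "measured", "known", "first", "only" and "open" are said of these compounds alone.

Measured in a functional assay on DU-145 cells (Homo sapiens) for cytotoxicity, read by trypan blue exclusion, with a stated time of 96 h; a lower number here means a stronger inhibitor, a higher number a weaker inhibitor
compound 1 `COc1cc(OC)c(/C=C/S(=O)(=O)Nc2ccc(OC)c(F)c2)c(OC)c1` gives 200 nM
compound 2 `COC(=O)C(Nc1cc(NS(=O)(=O)/C=C/c2c(OC)cc(OC)cc2OC)ccc1OC)c1ccc(Br)cc1` gives 7500 nM
compound 3 `COc1cc(OC)c(/C=C/S(=O)(=O)Nc2ccc(OC)c(NC(C)C(=O)O)c2)c(OC)c1` gives 40 nM

Compound 3 has the lowest number of the three (40 nM) and its steps to both others lie beyond the scatter. Compound 4 `COc1cc(OC)c(/C=C/S(=O)(=O)Nc2ccc(OC)c(NC(C(=O)O)c3ccc(F)cc3)c2)c(OC)c1` carries 4-fluorophenyl in place of methyl on a saturated chain carbon bound to a carbonyl carbon and a nitrogen on an aromatic ring. The closest evidence is the large step (a 190-fold lower number from compound 2 to compound 3 (2.27 log units; beyond the scatter)) but it changes the aromatic ring and the ester together, and the data do not separate the two. The modest step (a 5.0-fold lower number from compound 1 to compound 3 (0.70 log units; beyond the scatter)) sets the scale for a smaller change. A modest rise is therefore expected in this assay (a 3.8-fold higher number from compound 3 to compound 4 (0.57 log units; beyond the scatter)). Compound 4 is estimated at 150 nM (range 40 nM to 600 nM).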

Compound 4, half-maximal inhibitory concentration: 75 nM
Compound 4: middle estimate off by 2.0-fold (0.30 log units), on the high side, within the range that was stated.
By their numbers in this assay, from the lowest: compounds 3 and 4 (each within the scatter of the next); then compound 1; then compound 2.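

In this assay, the chain carbon bound to the carbonyl carbon and the aromatic nitrogen accepts 4-fluorophenyl in place of methyl with the step staying within the scatter (a 1.9-fold higher number from compound 3 to compound 4 (0.27 log units; within the scatter)). Carboxy(4-fluorophenyl)methyl keeps the large margin over the ester-bearing group (a 100-fold lower number from compound 2 to compound 4 (2.00 log units; beyond the scatter)), and (carboxy(4-fluorophenyl)methyl)amino still holds a modest margin over fluoro (a 2.7-fold lower number from compound 1 to compound 4 (0.43 log units; beyond the scatter)). No measurement bears on the reason for these steps.

The step from compound 2 still changes the ester and the ring halogen together. On these data alone, an amide in place of the carboxylic acid, or a longer alkyl chain in place of methyl, remains open.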